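Working notes: chloro in place of propyl

This account rests on a few compounds, and the source may have more. Where it says the series, first, only, none or still open, it means among the compounds named here.

In a functional assay on HeLa cells (Homo sapiens) for antiproliferative activity, read by sulforhodamine B assay, with a stated time of 48 h (on this read-out lower numbers stand for stronger inhibition of growth and higher numbers for weaker inhibition of growth), compound 2 (`CCCCCCc1cn(CCCN2C(=O)COc3ccccc32)nn1`) gives 100 nM, the lower of the two numbers in the series, and compound 3 (`CCCc1cn(CCCN2C(=O)COc3ccccc32)nn1`) gives 23200 nM. Among the measured compounds shown here, for compound 1 (`COc1ccc2cc(-c3cn(CCCN4C(=O)COc5ccccc54)nn3)ccc2c1`) the result is a limit, > 100000 nM, and not a number, so it gives no size of step.

Next in line is compound 4 (`O=C1COc2ccccc2N1CCCn1cc(CCCCl)nn1`), with this change from compound 2: chloro in place of propyl on a saturated chain carbon, three bonds along the chain from an aromatic carbon. Cut further out, the same difference reads hexyl to 3-chloropropyl.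

For the measured compounds named here, one measured step bears on this place on the chain: a 230-fold higher number from compound 2 to compound 3 (2.37 log units; beyond the scatter). That step removes the same propyl, with hydrogen entering where chloro enters in compound 4. Going by the values given here, only this single step supports the comparison, and no measured compound yet carries chloro, so the effect of chloro against hydrogen remains open. A large step in the same direction is therefore expected in this assay, of about the size of the step to compound 3. The estimated step is a 200-fold higher number from compound 2 to compound 4 (2.30 log units; beyond the scatter). A result reported only as a limit, as with compound 1, cannot be ruled out. The expected value for compound 4 is 20000 nM, with an estimated range of 3000 nM to 80000 nM.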

Compound 4, concentration for 50% growth inhibition: 100 nM
Compound 4: middle estimate off by 200-fold (2.30 log units), on the high side; the measured number lies below the stated range.
By their numbers in this assay, from the lowest: compounds 2 and 4 (each within the scatter of the next); then compound 3. At a limit, above all of these: compound 1.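

In this assay, among the compounds shown here, the step from propyl to 3-chloropropyl changes the picture left by compounds 2 and 3, where the only measured change at this place was the large loss on going to the shorter chain. Chloro in place of propyl gives no change at the digits printed from compound 2 to compound 4 (within the scatter), so 3-chloropropyl and hexyl cannot be told apart here, even though chloro is 1 heavy atom and the propyl it replaces is 3 heavy atoms. Chloro in place of hydrogen on a saturated chain carbon, three bonds along the chain from an aromatic carbon, gives a 230-fold lower number from compound 3 to compound 4 (2.37 log units; beyond the scatter), which shows that the number at this place does not follow the removal of propyl alone and that the atom entering there can outweigh that removal.

Nothing shown gives a reason for the result, and the single chloro compound cannot say whether the effect belongs to chloro itself or to any group at this chain carbon. Going by these compounds, whether bromo, a hydroxyl, an amine or a carboxylic acid at the same chain carbon, or chloro on a longer chain, would behave like chloro in compound 4 stays open.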